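Phenyl for propyl on the isoxazole of a deoxynucleoside series

The source may report more compounds than this note shows. Statements on the series, on what has been measured and on what is new or still open speak of the compounds shown alone.

Measured so far:
compound 1, `CC(=O)OC[C@H]1O[C@@H](n2cc(-c3cn(Cc4ccc(C(C)(C)C)cc4)nn3)c(=O)[nH]c2=O)C[C@@H]1OC(C)=O`, 106%
compound 2, `CCCc1cc(-c2cn([C@H]3C[C@H](OC(C)=O)[C@@H](COC(C)=O)O3)c(=O)[nH]c2=O)on1`, 96.9%

Two compounds have numbers. In a functional assay on NCI-H23 cells (Homo sapiens) for cytotoxicity, read by sulforhodamine B assay, tested at 10 uM (on this read-out higher numbers stand for more inhibition at the one concentration tested (going by the name of the read-out) and lower numbers for less inhibition), compound 1 gives 106%. In this assay compound 2 gives 96.9%. The two values lie within the usual scatter of each other, so compound 2 is not set apart from compound 1 on this read-out; both numbers are high at the single concentration tested. Within the data shown here, no pair of measured compounds differs in only one place, so no single measured step is available to calibrate the next change.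

Compound 3, `CC(=O)OC[C@H]1O[C@@H](n2cc(-c3cc(-c4ccccc4)no3)c(=O)[nH]c2=O)C[C@@H]1OC(C)=O`, has not been measured. Against compound 2 it carries phenyl in place of propyl on an aromatic carbon.

Among the measured compounds shown here, with both measured compounds giving high numbers and no measured step of comparable kind, the expectation for compound 3 is an outcome near that of compound 2, with the step of a number 1.9 percentage points lower from compound 2 to compound 3 (within the scatter) expected to stay within the scatter in either direction. Compound 3 is estimated at 95%, with a range from 75% to 108%.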

Compound 3, a percentage reported as inhibition, at one concentration (the size of the read-out at that concentration, not a potency): 91.4%
For compound 3 the middle estimate is 3.6 percentage points above the measured one; the measured number falls inside the stated range.
By their numbers in this assay, from the lowest: compounds 3, 2 and 1 (each within the scatter of the next, the first and the last beyond it).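

In this assay, among these compounds, replacing 3-propyl-1,2-oxazol-5-yl with 3-phenyl-1,2-oxazol-5-yl gives a number 5.5 percentage points lower from compound 2 to compound 3 (within the scatter), the first step that can be read between two compounds differing in one place. On this aromatic carbon next to the ring nitrogen, a propyl chain and a phenyl ring therefore cannot be told apart at the single concentration tested, and this one step shows that adding a six-membered aromatic ring of carbon only here does not take the read-out beyond the scatter. No measurement on hand explains why the two groups read alike.

From the compounds shown here alone, whether an amine, a carboxylic acid or a longer chain at this position would also stay within the scatter of compound 2 remains open. Also open, going by these compounds, is whether compound 2 and compound 3 would separate across a range of concentrations, and compound 1 differs from both in more than one place, so it gives no reading on this position.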